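Adding 2,5-difluorophenyl to compound 3

This account rests on a few compounds, and the source may have more. Where it says the series, first, only, none or still open, it means among the compounds named here.

Measured in an ADME assay on MT4 cells (Homo sapiens) for cytotoxicity, read by MTT assay, with a stated time of 96 h; a higher number here means that more compound is tolerated, a lower number that less compound is tolerated:
Compound 1 `Fc1ccc(F)c(/N=N/Nc2cccc(C(F)(F)F)c2)c1`: > 100000 nM
Compound 2 `CN(C)CCCN(/N=N/c1cc(F)ccc1F)c1ccccc1`: 13000 nM
Compound 3 `CN(C)CCCN(/N=N/c1ccccc1)c1cccc(C(F)(F)F)c1`: 14000 nM

Compound 1 gives only a limit of this assay, > 100000 nM. Compound 3, at 14000 nM, lies within the usual scatter of compound 2, at 13000 nM.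

Compound 4 `CN(C)CCCN(/N=N/c1cc(F)ccc1F)c1cccc(C(F)(F)F)c1` carries 2,5-difluorophenyl in place of phenyl on a double-bonded nitrogen. Among the measured compounds shown here, no measured pair isolates this change. Compound 2 also carries 2,5-difluorophenyl and gives 13000 nM, so no step beyond the scatter is expected in this assay. The expected result is a 1.3-fold lower number from compound 3 to compound 4 (0.10 log units; within the scatter). For compound 4 the estimated value is 11000 nM, with an expected range of 4500 nM to 25000 nM.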

Compound 4, half-maximal cytotoxic concentration: 16000 nM
Beside the measured number, compound 4's estimate is 1.5-fold (0.16 log units) below it; the range from low to high includes it.
By their numbers in this assay, from the lowest: compounds 2, 3 and 4 (each within the scatter of the next). At a limit, above all of these: compound 1.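

In this assay, 2,5-difluorophenyl in place of phenyl on a double-bonded nitrogen now has a pair that isolates it, and it gives a 1.1-fold higher number from compound 3 to compound 4 (0.06 log units; within the scatter), while trifluoromethyl in place of hydrogen on an aromatic carbon gives a 1.2-fold higher number from compound 2 to compound 4 (0.09 log units; within the scatter). Among the compounds shown here, the only step beyond the scatter comes with 3-(dimethylamino)propyl in place of hydrogen on a nitrogen on an aromatic ring, an at least 6.2-fold lower number from compound 1 to compound 4 (0.79 log units; beyond the scatter). Compound 1 stands at a limit of the assay, not at a number: the limit of > 100000 nM in this assay, at which 1 of the 4 values shown sits.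

Open, from the compounds shown here alone, is whether a shorter chain or a morpholine in place of the dimethylamino group would keep this step. Also open, going by these compounds, is how a chlorine or methoxy group on the phenyl ring would read.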